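The compounds below may be only part of what the source reports. "The series", "measured", "known", "first", "only" and "open" are said of these compounds alone.

Measured so far in an ADME assay on L6 cells (Rattus norvegicus) for cytotoxicity; on this read-out lower numbers stand for stronger inhibition and higher numbers for weaker inhibition:
- compound 1 `CN1CCN(CCC(=O)OC2CC3(N(C)C)CC(c4ccccc4)C2C(c2ccccc2)C3)CC1`: 31100 nM
- compound 2 `CN1CCN(CCCC(=O)OC2CC3(N(C)C)CC(c4ccccc4)C2C(c2ccccc2)C3)CC1`: 19900 nM

Only these two values exist, and compound 1 sits level with compound 2 within the scatter, so the series shows no clear order yet. Among the compounds with values here, the single measured step, a 1.6-fold lower number from compound 1 to compound 2 (0.19 log units; within the scatter), lies within the scatter and concerns a saturated chain carbon, not the site changed next.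

Compound 3 `CN1CCN(CCC(=O)OC2CC3(N4CCCCC4)CC(c4ccccc4)C2C(c2ccccc2)C3)CC1` keeps the rest of compound 1 and carries piperidin-1-yl in place of dimethylamino on a saturated ring carbon. Within the data shown here, no measured step covers a change at this ring carbon, so the evidence is indirect and the range stays wide. No shift beyond the scatter is expected in this assay. The estimated step is a 1.4-fold lower number from compound 1 to compound 3 (0.15 log units; within the scatter). The expected value for compound 3 is 22000 nM, with an estimated range of 8000 nM to 60000 nM.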

Compound 3, half-maximal inhibitory concentration: 23500 nM
Estimate against measurement, compound 3: 1.1-fold (0.03 log units) below; the measured number falls inside the stated range.
By their numbers in this assay, from the lowest: compounds 2, 3 and 1 (each within the scatter of the next).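

In this assay, within the data shown here, the first reading at this saturated ring carbon gives a 1.3-fold lower number from compound 1 to compound 3 (0.12 log units; within the scatter). Within this pair, piperidin-1-yl in place of dimethylamino brings in a six-membered non-aromatic ring and raises the group from 3 to 6 heavy atoms, with no shift beyond the scatter. No available data offer an explanation for this result.

Pyrrolidin-1-yl and morpholin-4-yl at the same ring carbon would show whether this level read-out extends to other ring amines, and a primary amine would test the position with a much smaller group. Also open, from the compounds shown here alone, is whether piperidin-1-yl at this ring carbon gives a comparable read-out when paired with the (4-methylpiperazin-1-yl)methyl chain of compound 2.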